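Carboxyphenyl shift on the shared core

A few compounds are considered here, and "the series" means these few. Any claim that something is new, unique, unknown or untested is made for them only; others in the source may bear on it.

Compound 2 `CC(C)c1onc(-c2c(Cl)cccc2Cl)c1COc1cnc(N(C)Cc2ccc(C(=O)O)cc2)c(Cl)c1` gives 242 nM in an assay on isolated protein for agonist activity at Bile acid receptor (Homo sapiens), read by FRET (a lower number here means that less compound is needed, a higher number that more compound is needed for the effect), the higher of the two numbers recorded so far; compound 1 `CC(C)c1onc(-c2c(Cl)cccc2Cl)c1COc1ccc(N(C)Cc2ccc(C(=O)NS(C)(=O)=O)cc2)c(C(F)(F)F)n1` gives 40 nM in this assay, and the gap between the two lies beyond the usual scatter. Compound 3 `CC(C)c1onc(-c2c(Cl)cccc2Cl)c1COc1cnc(N(C)Cc2cccc(C(=O)O)c2)c(Cl)c1` is not yet measured. It differs from compound 2 by 3-carboxyphenyl in place of 4-carboxyphenyl on a saturated chain carbon bound to a nitrogen on an aromatic ring. Going by the values given here, no pair of measured compounds differing in a single place exists here, so this step has no precedent. The change is expected to raise the number, probably beyond the scatter, though a flat outcome cannot be excluded. The expected step is a 2.9-fold higher number from compound 2 to compound 3 (0.46 log units; beyond the scatter). Compound 3 is thus estimated at 700 nM, within a range of 200 nM to 2500 nM.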

Compound 3, half-maximal effective concentration: 190 nM
Compound 3: middle estimate off by 3.7-fold (0.57 log units), on the high side; the whole stated range lies above it.
By their numbers in this assay, from the lowest: compound 1; then compounds 3 and 2 (each within the scatter of the next).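

In this assay, 3-carboxyphenyl in place of 4-carboxyphenyl on a saturated chain carbon bound to a nitrogen on an aromatic ring gives a 1.3-fold lower number from compound 2 to compound 3 (0.11 log units; within the scatter). This first single-place comparison in the series shows that this place tolerates either carboxyphenyl arrangement, with no separation between the two in this assay. Nothing at hand explains the result.

Open, from the compounds shown here alone, is whether a tetrazole in place of the carboxylic acid, or a longer chain at this place, would hold the reading. Compound 1 differs from compound 2 and compound 3 in more than one place, so its separate reading cannot be assigned to any one change.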